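Selenium chain in place of thiol: growth inhibition notes

The source may hold more compounds than are shown below. What is called first, only, known or untested is meant among the compounds shown, and "the series" means these compounds.

Measured so far:
- compound 1, `CCCCC[Se]c1nc(NCc2ccc(SC)cc2)c2ccccc2n1`: 81300 nM
- compound 2, `Sc1nc(NCc2ccccc2)c2ccccc2n1`: > 100000 nM (limit only)

In a functional assay on HTB-54 cells (Homo sapiens) for cytotoxicity, read by MTT assay, with a stated time of 72 h (on this read-out lower numbers stand for stronger inhibition of growth and higher numbers for weaker inhibition of growth), compound 1 gives 81300 nM. For compound 2 this assay reports no number but only a limit, > 100000 nM. This is the limit of > 100000 nM in this assay, at which 1 of the 2 values shown sits, so compound 2 stands at the weak end of what is shown, without a fixed value.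

Compound 3, `CCCCC[Se]c1nc(NCc2ccccc2)c2ccccc2n1`, differs from compound 2 by a group of 6 heavy atoms (5 carbon, 1 selenium; no ring) in place of one sulfur atom, on an aromatic carbon, between two ring nitrogen atoms. Within the data shown here, no measured step between compounds that differ in one place is available, so the size of this step can only be expected, not read off. Compound 1 carries the same chain on the same core and gives 81300 nM, a number rather than a limit. The step from compound 2 to compound 3 is therefore expected to be an at least 1.1-fold lower number from compound 2 to compound 3 (0.07 log units; that floor lies within the scatter), a modest move toward stronger inhibition of growth, with a real chance that this assay again returns only a limit. Compound 3 is expected at 85000 nM, within 40000 nM to 200000 nM.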

Compound 3, concentration for total growth inhibition: 81100 nM
Estimate against measurement, compound 3: 1.0-fold (0.02 log units) above; the range from low to high includes it.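

The selenium chain in place of sulfanyl, on an aromatic carbon between two ring nitrogen atoms, can now be read as a step in this assay: the change gives an at least 1.2-fold lower number from compound 2 to compound 3 (0.09 log units; that floor lies within the scatter) and so has only a floor, with no size yet. Compound 2 stands as a limit and not as a number: the limit of > 100000 nM in this assay, at which 1 of the 3 values shown sits. The second pair adds what compound 1 alone could not show, as hydrogen in place of methylsulfanyl on an aromatic carbon gives a 1.0-fold lower number from compound 1 to compound 3 (0.00 log units; within the scatter) and leaves the two compounds indistinguishable in this assay, so on this pair the methylsulfanyl group makes no readable difference.

Open, from the compounds shown here alone, is whether the same chain held through sulfur rather than selenium, a shorter or longer chain on selenium, or an amine on that carbon would give a number clearly apart from that of compound 3. Also open, going by these compounds, are the true size of the step from the sulfanyl compound and whether a carboxylic acid or an amine in place of methylsulfanyl would move the number at all.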